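A few compounds are considered here, and "the series" means these few. Any claim that something is new, unique, unknown or untested is made for them only; others in the source may bear on it.

Measured so far:
compound 1, `COc1ccc(-c2nc(SC)n(C)c(=O)c2C#N)cc1`: in a functional assay, with a stated time of 10 min (on this read-out higher numbers stand for weaker inhibition and lower numbers for stronger inhibition), compound 1 gives 48 ug/mL
compound 2, `CCOC(=O)c1cnn(-c2nc(-c3ccc(OC)cc3)c(C#N)c(=O)n2C)c1N`: in this assay compound 2 gives 74 ug/mL

On these two numbers compound 2 is not set apart from compound 1: the gap between them lies within the usual scatter of repeated measurements, so the two cannot be told apart. Among the measured compounds shown here, no step between measured compounds that differ in one place is available, so nothing measured here shows how a single change moves the read-out.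

Compound 3, `CCOC(=O)c1cnn(-c2nc(-c3ccccc3O)c(C#N)c(=O)n2C)c1N`, has not yet been measured. It differs from compound 2 in one place: 2-hydroxyphenyl in place of 4-methoxyphenyl on an aromatic carbon. Neither measured compound carries a hydroxyphenyl group, so there is nothing to anchor the size of this change. The step of a 1.1-fold lower number from compound 2 to compound 3 (0.02 log units; within the scatter) is therefore expected to be small, none beyond the scatter. Compound 3 is estimated at 70 ug/mL, with a range from 30 ug/mL to 160 ug/mL.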

Compound 3, half-maximal inhibitory concentration: 58 ug/mL
For compound 3 the middle estimate is 1.2-fold (0.08 log units) above the measured one; the measured number falls inside the stated range.
By their numbers in this assay, from the lowest: compounds 1, 3 and 2 (each within the scatter of the next).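

This is the only one-place comparison shown in this assay: putting 2-hydroxyphenyl in place of 4-methoxyphenyl on the aromatic carbon ortho to a cyano group gives a 1.3-fold lower number from compound 2 to compound 3 (0.11 log units; within the scatter), so the two compounds cannot be told apart. The exchange removes a methyl group, moves the oxygen to a different place on the phenyl ring and adds a hydrogen-bond donor, yet the read-out shows no difference beyond the scatter. No measurement is available that would explain this result.

Because the kind of oxygen group and its place on the phenyl ring change together, the compounds shown do not separate these two changes. From the compounds shown here alone, how 4-hydroxyphenyl, 2-methoxyphenyl or an aminophenyl group would read out at this position remains open.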